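Expected effect of ethyl on the carboxy group of compound 2

A few compounds are considered here, and "the series" means these few. Any claim that something is new, unique, unknown or untested is made for them only; others in the source may bear on it.

Measured in an ADME assay on Vero cells (Chlorocebus sabaeus) for cytotoxicity, read by fluorescence and resazurin assay, with a stated time of 3 days (a lower number here means that less compound is tolerated, a higher number that more compound is tolerated), so far
Compound 1 `COC(=O)C[C@H]([C@H]1O[C@@H]2OC(C)(C)O[C@@H]2[C@H]1OCc1ccccc1)n1cnc2c(N)ncnc21` gives 86300 nM
Compound 2 `CC1(C)O[C@H]2O[C@H]([C@H](CC(=O)O)n3cnc4c(N)ncnc43)[C@H](Oc3ccccc3N)[C@H]2O1` gives 67100 nM
Compound 3 `CCOC(=O)C[C@H]([C@H]1O[C@@H]2OC(C)(C)O[C@@H]2[C@H]1Oc1ccccc1[N+](=O)[O-])n1cnc2c(N)ncnc21` gives 119000 nM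

For the measured compounds named here, compound 2 stands within the usual scatter of both compound 1 and compound 3, so these three values set up no order among the compounds. Compound 4 `CCOC(=O)C[C@@H]([C@H]1O[C@@H]2OC(C)(C)O[C@@H]2[C@H]1Oc1ccccc1N)n1cnc2c(N)ncnc21` differs from compound 2 by one change (ethyl in place of hydrogen on an oxygen next to a carbonyl group) with ethyl in place of hydrogen on an oxygen next to a carbonyl group. This turns carboxy into ethoxycarbonyl. Going by the values given here, no pair of measured compounds shows this change alone. Compound 3 also carries ethoxycarbonyl, and its value (119000 nM) lies within the scatter of the value of compound 2 (67100 nM). No step beyond the scatter is therefore expected in this assay for this change. The estimate corresponds to an expected step (a 1.3-fold higher number from compound 2 to compound 4 (0.13 log units; within the scatter)) that stays within the scatter. For compound 4 the estimated value is 90000 nM with an expected range from 40000 nM to 200000 nM before the measurement is known.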

Compound 4, half-maximal cytotoxic concentration: 89700 nM
Beside the measured number, compound 4's estimate is 1.0-fold (0.00 log units) above it, within the range that was stated.
By their numbers in this assay, from the lowest: compounds 2, 1, 4 and 3 (each within the scatter of the next).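

In this assay, the carboxy group of compound 2 and the ethoxycarbonyl group of compound 4 can now be compared as a single change, which gives a 1.3-fold higher number from compound 2 to compound 4 (0.13 log units; within the scatter). For the compounds shown here, at this position, then, ethyl in place of hydrogen on an oxygen next to a carbonyl group leaves the reading within the scatter, whereas the earlier compounds differed in more than one place and could not isolate this change. No measurement given here accounts for the result.

The compounds shown leave open whether a longer chain on this oxygen, such as butyl, or an amide in place of the ester would also stay within the scatter. They also leave open whether the same change would read alike on the core of compound 1.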